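Swapping the ortho methoxy for chloro on a dihydropyridine

This account rests on a few compounds, and the source may have more. Where it says the series, first, only, none or still open, it means among the compounds named here.

Two compounds share one core and differ only in the group on the pendant phenyl ring. Compound 1 `N#CC1=C(N)N(c2ccc(S(N)(=O)=O)cc2)C2=C(CCCC2)C1c1ccccc1` carries a plain phenyl ring; in a functional assay on Ehrlich cells (Mus musculus) for cytotoxicity, read by trypan blue exclusion, with a stated time of 2 h, tested at 10 ug/mL (on this read-out higher numbers stand for a stronger effect at the one concentration tested and lower numbers for a weaker effect), compound 1 gives 5%. Compound 2 `COc1ccccc1C1C(C#N)=C(N)N(c2ccc(S(N)(=O)=O)cc2)C2=C1CCCC2` carries a methoxy on that ring, and in this assay compound 2 gives 30%. Going by the values given here, the only measured step, a number 25 percentage points higher from compound 1 to compound 2 (beyond the scatter), came with methoxy in place of hydrogen on an aromatic carbon. Among the two numbers, compound 2 stands highest.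

Compound 3 `N#CC1=C(N)N(c2ccc(S(N)(=O)=O)cc2)C2=C(CCCC2)C1c1ccccc1Cl` is the next step, differing from compound 2 by chloro in place of methoxy on an aromatic carbon. Among the compounds with values here, no measured step involves chloro, so the one known step is only a loose guide: it shows that a group on this ring can matter. Because a number 25 percentage points higher from compound 1 to compound 2 (beyond the scatter) was modest, the expected step of a number 10 percentage points lower from compound 2 to compound 3 (within the scatter) for compound 3 is a small decrease, within or near the scatter. Compound 3 is estimated to give 20%, ranging from 5% to 40%.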

Compound 3, a percentage reported as activity, at one concentration (the size of the read-out at that concentration, not a potency): 0%
Estimate against measurement, compound 3: 20 percentage points above; the whole stated range lies above it.
By their numbers in this assay, from the lowest: compounds 3 and 1 (each within the scatter of the next); then compound 2.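

In this assay, the rise seen with methoxy does not extend to every group placed on this ring carbon: a number 30 percentage points lower from compound 2 to compound 3 (beyond the scatter). So what counts here is which group is present, not simply that the hydrogen has been replaced, and chloro offers no gain over the plain ring: a number 5 percentage points lower from compound 1 to compound 3 (within the scatter). No measurement available here explains why methoxy and chloro part ways.

The compounds shown leave open whether a hydroxyl, an amine or an ethoxy group at this place would match methoxy or stay level with hydrogen and chloro. They also leave open whether the difference between methoxy and chloro would hold at other concentrations, since each compound has a reading at only one.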